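Methyl for Methoxy on a Fused Aromatic Core

A few compounds are considered here, and "the series" means these few. Any claim that something is new, unique, unknown or untested is made for them only; others in the source may bear on it.

Measured compounds:
Compound 1, `COc1c(OC)c(OC(C)=O)c2ccccc2c1OC(C)=O`, gives 2.39 in a physicochemical assay for lipophilicity; a higher number here means a more lipophilic compound, a lower number a more polar compound.
Compound 2, `COc1c(OC)c(OC(C)=O)c2cc(Br)ccc2c1OC(C)=O`, gives 3.39 in this assay.
Compound 3, `COc1ccc2c(OC(C)=O)c(OC)c(OC)c(OC(C)=O)c2c1`, gives 2.39 in this assay.

Compound 3 stands level with compound 1, the two together being the lowest of the three numbers, and compound 2 sits above them: a number 1.00 log units lower from compound 2 to compound 3 (beyond the scatter). The unmeasured compound 4, `COc1c(OC)c(OC(C)=O)c2cc(C)ccc2c1OC(C)=O`, differs from compound 3 by methyl in place of methoxy on an aromatic carbon.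

Among the compounds with values here, no measured step places methyl against methoxy directly, so the expectation rests on what the neighbouring steps show. Adding methoxy to the core of compound 1 left the reading where it was: no change at the digits printed from compound 1 to compound 3 (within the scatter). Adding bromo instead moved it clearly: a number 1.00 log units higher from compound 1 to compound 2 (beyond the scatter). A methyl at the same kind of position is expected to fall between these outcomes, a modest rise rather than no change.

Compound 4 is therefore expected at 2.9, within a range of 2.4 to 3.4. This estimate means a step of a number 0.51 log units higher from compound 3 to compound 4 (beyond the scatter) in this assay.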

Compound 4, partition coefficient: 2.86
Beside the measured number, compound 4's estimate is 0.04 log units above it; the range from low to high includes it.
By their numbers in this assay, from the lowest: compounds 1 and 3 (each within the scatter of the next); then compound 4; then compound 2.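

Within the data shown here, compound 4 gives the first direct comparison of methyl and methoxy at this position on the shared core, and in this assay the exchange gives a number 0.47 log units higher from compound 3 to compound 4 (beyond the scatter) and lies beyond the scatter. Measured against the unsubstituted core, methyl gives a number 0.47 log units higher from compound 1 to compound 4 (beyond the scatter) where methoxy left the reading unchanged, so at this position not every added group moves the number. Bromo still stands clear of methyl, with a number 0.53 log units lower from compound 2 to compound 4 (beyond the scatter), which places the three groups and hydrogen on two separate steps above the level shared by compound 1 and compound 3, and no evidence is available to explain this order.

Going by these compounds, whether the same order holds elsewhere on the core remains open. So does where an amine, a carboxylic acid or a longer chain such as propyl would fall at this position in this assay.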